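Oxime geometry in a hydroxylated pyridinylpiperazine series

The source may hold more compounds than are shown below. What is called first, only, known or untested is meant among the compounds shown, and "the series" means these compounds.

Measured so far:
compound 1 `CO/N=C(\CCN1CCN(c2ccccn2)CC1)c1ccc(Cl)cc1` gives 87% in a functional assay on HEK293 cells with D(4) dopamine receptor (Homo sapiens) as the target, read by FLIPR; on this read-out higher numbers stand for larger maximal responses and lower numbers for smaller maximal responses;
compound 2 `CO/N=C(/CCN1CCN(c2ccccn2)CC1)c1ccc(Cl)cc1` gives 68%;
compound 3 `CO/N=C(\c1ccc(Cl)cc1)C(O)CN1CCN(c2ccccn2)CC1` gives 89%.

Compound 3 stands at the upper end of the three numbers; compound 1 lies within the scatter of it, while compound 2 sits beyond the scatter below it. The step from compound 2 to compound 3 was a number 21 percentage points higher from compound 2 to compound 3 (beyond the scatter).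

Compound 4 `CO/N=C(/c1ccc(Cl)cc1)C(O)CN1CCN(c2ccccn2)CC1` differs from compound 3 as the two compounds have the same atoms and bonds; at least one stereo element is drawn with a configuration in one of them and without one in the other: 1 of 2 stereo elements differ; a double bond is drawn E in compound 3 and Z in compound 4. Among the measured compounds shown here, the only measured step of the same kind is a number 19 percentage points lower from compound 1 to compound 2 (beyond the scatter), which rests on (the fact that compounds 1 and 2 differ only in the configuration as drawn). A change of similar size and direction is therefore expected here: a number 19 percentage points lower from compound 3 to compound 4 (beyond the scatter). Compound 4 is estimated at 70%, within 55% to 85%.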

Compound 4, largest response reached (reported as efficacy), in percent of the reference or control that the assay uses: 94%
For compound 4 the middle estimate is 24 percentage points below the measured one; the whole stated range lies below it.
By their numbers in this assay, from the lowest: compound 2; then compounds 1, 3 and 4 (each within the scatter of the next).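

In this assay, the change from E to Z at the oxime double bond gave a number 19 percentage points lower from compound 1 to compound 2 (beyond the scatter) without the hydroxy, but with it gives a number 5 percentage points higher from compound 3 to compound 4 (within the scatter), so the drop does not carry over to the hydroxy compounds. Hydroxy in place of hydrogen on the Z-drawn oxime compounds has already been seen; on the E-to-Z-matched pair it gives a number 7 percentage points higher from compound 1 to compound 4 (within the scatter), and the two readings of this change do not separate: the same change on two cores in this assay, a number 21 percentage points higher (beyond the scatter) from compound 2 to compound 3 and a number 7 percentage points higher (within the scatter) from compound 1 to compound 4, 14 percentage points apart, within the scatter of two such steps. The geometry comparison at this position also carries a caveat: the fact that one of compounds 3 and 4 is drawn with a defined configuration and the other without, at the place where they differ.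

Open, from the compounds shown here alone, is whether an amine in place of the hydroxy on the chain carbon would behave as the hydroxy does. Also open, going by these compounds, is the effect of a longer chain on the oxime oxygen, such as ethyl in place of methyl, on either double-bond geometry.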